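A few compounds are considered here, and "the series" means these few. Any claim that something is new, unique, unknown or untested is made for them only; others in the source may bear on it.

Working notes on a small series sharing one core. Compound 1 `O=c1[nH]c2ccccc2cc1/C=N/c1ccccc1O` gives 22800 nM in a functional assay, read by spectrophotometry, with a stated time of 30 min; a higher number here means a weaker inhibitor, a lower number a stronger inhibitor. Compound 2 `Cc1ccc2[nH]c(=O)c(/C=N/c3ccccc3O)cc2c1` gives 26200 nM in this assay, and compound 3 `NS(=O)(=O)c1ccc(/N=C/c2cc3ccccc3[nH]c2=O)cc1` gives 266000 nM. Compound 2 thus stands second highest of the three numbers; its nearest neighbour is compound 1, within the scatter, while the gap from compound 2 to compound 3 lies beyond it. Going by the values given here, the only single-point step measured so far is a 1.1-fold higher number from compound 1 to compound 2 (0.06 log units; within the scatter), which changes nothing beyond the scatter.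

Compound 4 `Cc1ccc2[nH]c(=O)c(/C=N/N)cc2c1` has not yet been measured in this assay. It differs from compound 2 in one place: amino in place of 2-hydroxyphenyl on a double-bonded nitrogen. Among the compounds with values here, no measured step bears on this change directly; the one step on record, a 1.1-fold higher number from compound 1 to compound 2 (0.06 log units; within the scatter), concerns a methyl on the core and says nothing about the group on the double-bonded nitrogen. Compound 1 and compound 3 carry different groups on that nitrogen and their numbers stand far apart, which only shows that this position can move the read-out widely. Removing the 2-hydroxyphenyl altogether leaves little to hold the number down, so a step toward a higher number in this assay is expected, of uncertain size. The estimate for compound 4 is 70000 nM, with a range from 20000 nM to 250000 nM. This corresponds to an expected step of a 2.7-fold higher number from compound 2 to compound 4 (0.43 log units; beyond the scatter).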

Compound 4, half-maximal inhibitory concentration: 641000 nM
For compound 4 the middle estimate is 9.2-fold (0.96 log units) below the measured one; measured number outside the range, above it.
By their numbers in this assay, from the lowest: compounds 1 and 2 (each within the scatter of the next); then compound 3; then compound 4.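

Swapping the 2-hydroxyphenyl for amino on the double-bonded nitrogen, with the core held constant, gives a 24-fold higher number from compound 2 to compound 4 (1.39 log units; beyond the scatter) in this assay, so this position can move the read-out by a large step in a single change. The methyl change on the core, a 1.1-fold higher number from compound 1 to compound 2 (0.06 log units; within the scatter), stays within the scatter, which makes the group on the double-bonded nitrogen the only one of the two changed places shown to matter so far. The change removes the six-membered aromatic ring and most of the group's heavy atoms, while the hydrogen-bond donor and acceptor counts of the two groups match, so those counts alone do not follow the read-out, and no measurement at hand accounts for the step.

The compounds shown leave open whether the difference goes with the ring or with its hydroxyl, and an unsubstituted phenyl or a short alkyl chain such as ethyl on the double-bonded nitrogen would separate the two. Also open, from the compounds shown here alone, is whether amino in place of 2-hydroxyphenyl gives a step of similar size on the core of compound 1, which lacks the methyl.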